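Swapping the amide aryl group: tert-butylphenyl to furan

A few compounds are considered here, and "the series" means these few. Any claim that something is new, unique, unknown or untested is made for them only; others in the source may bear on it.

Compound 1: `CCOC(=O)c1sc(-c2cccc(NC(=O)c3ccc(C(C)(C)C)cc3)c2)nc1Nc1ccc(N2CCN(C)CC2)cc1` — "not determined" (no result reported) in a functional assay on Raji cells (Homo sapiens) for antiproliferative activity, read by CCK-8 assay, with a stated time of 72 h; on this read-out higher numbers stand for weaker inhibition and lower numbers for stronger inhibition.
Compound 2: `CCOC(=O)c1sc(-c2cccc(NC(=O)c3ccccc3F)c2)nc1Nc1ccc(N2CCN(C)CC2)cc1` — 9270 nM in this assay.
Compound 3: `CN1CCN(c2ccc(Nc3nc(-c4cccc(NC(=O)c5ccc(C(C)(C)C)cc5)c4)sc3C(N)=O)cc2)CC1` — "not determined" (no result reported) in this assay.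

Of the three measured compounds, only compound 2 gives a number in this assay; compound 1 and compound 3 were tested but no single value was reported for either, so compound 3 stands without a number of its own. Compound 4 is `CN1CCN(c2ccc(Nc3nc(-c4cccc(NC(=O)c5ccco5)c4)sc3C(N)=O)cc2)CC1`. It differs from compound 3 in one place: furan-2-yl in place of 4-(tert-butyl)phenyl on a carbonyl carbon. Going by the values given here, no pair of measured compounds differs in only one place, so there is no measured step to lean on, and the size and direction of the change from compound 3 to compound 4 cannot be read from the data. A step of modest size in either direction, or none beyond the usual scatter, would be equally consistent with what is known. Taking the one number available, that of compound 2, as the only anchor, compound 4 is expected to give about 6000 nM, with a wide range from 1000 nM to 30000 nM.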

Compound 4, half-maximal inhibitory concentration: 37400 nM
Compound 4: middle estimate off by 6.2-fold (0.79 log units), on the low side, and the stated range ends below it.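

Going by these compounds alone, compound 3 has no single number in this assay and so no step to compound 4 can be read. No other measurement shown bears on this result. Going by these compounds, whether furan-2-yl in place of 4-(tert-butyl)phenyl shifts the read-out at all, and in which direction, stays open.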